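Replacing a Dimethylamino Chain with Methylsulfanyl

A few compounds are considered here, and "the series" means these few. Any claim that something is new, unique, unknown or untested is made for them only; others in the source may bear on it.

Compound 1 `CCOCC1CN(c2ccccc2)NC1=O` and compound 2 `CCCOCC1CN(c2ccccc2)NC1=O` share a core that carries a phenyl group on one ring nitrogen and a short ether-bearing chain on a ring carbon. In an assay on isolated protein for inhibition of Polyunsaturated fatty acid 5-lipoxygenase (Rattus norvegicus) (a higher number here means a weaker inhibitor, a lower number a stronger inhibitor), compound 1 gives 280 nM, and compound 2 gives 260 nM; the step between them is a 1.1-fold lower number from compound 1 to compound 2 (0.03 log units; within the scatter). Compound 3 `CN(C)CCC1CN(c2ccccc2)NC1=O` carries a 2-(dimethylamino)ethyl chain in that place instead. For compound 3 this assay reports only > 1000 nM, which is the limit of > 1000 nM in this assay, at which 1 of the 3 values shown sits, rather than a number. Compound 3 therefore stands as the weakest of the three measured compounds: the steps into it were an at least 3.5-fold higher number from compound 1 to compound 3 (0.55 log units; beyond the scatter) and an at least 3.8-fold higher number from compound 2 to compound 3 (0.58 log units; beyond the scatter).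

Compound 4 `CSC1CN(c2ccccc2)NC1=O` is not yet measured. It differs from compound 3 by methylsulfanyl in place of 2-(dimethylamino)ethyl on a saturated ring carbon. The two measured steps into compound 3 both raised the number by at least a modest amount when an ether chain was exchanged for the 2-(dimethylamino)ethyl chain, so taking that chain away again is expected to move the number back down, though methylsulfanyl is a smaller group than either ether chain. The step from compound 3 to compound 4 is expected to be an at least 2.5-fold lower number from compound 3 to compound 4 (0.39 log units; beyond the scatter). Compound 4 is expected to give about 400 nM in this assay, within a range from 150 nM to 1500 nM.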

Compound 4, half-maximal inhibitory concentration: 320 nM
The estimate for compound 4 lay 1.3-fold (0.10 log units) above the measured number; low and high end bracket the measured number.
By their numbers in this assay, from the lowest: compounds 2, 1 and 4 (each within the scatter of the next). At a limit, above all of these: compound 3.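

Methylsulfanyl, placed directly on the saturated ring carbon, gives a result in this assay that cannot be told apart from those of the two longer ether chains: the steps are a 1.2-fold higher number from compound 2 to compound 4 (0.09 log units; within the scatter) and a 1.1-fold higher number from compound 1 to compound 4 (0.06 log units; within the scatter), so among these compounds neither an ether oxygen nor a chain of that length is needed at this position. The step away from the amine-bearing chain is an at least 3.1-fold lower number from compound 3 to compound 4 (0.49 log units; beyond the scatter), which shows that the shared core keeps this level with a small group in place, and that compound 3 is the only one of the four that stands apart. The size of that step is a bound and not an exact figure, as compound 3 sits at a limit: the limit of > 1000 nM in this assay, at which 1 of the 4 values shown sits.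

The compounds shown cannot separate the effect of the dimethylamino nitrogen in compound 3 from the effect of its chain, a question that a plain butyl chain of carbon atoms or a carboxylic acid on a similar chain could address. As far as these compounds go, it also remains open how far this position would hold its level with a bare hydrogen or a longer sulfur-linked chain such as ethylsulfanyl, and what a substituent on the phenyl group would do.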